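Dihydroxyphenyl exchange on a compound at the assay limit

The source may report more compounds than this note shows. Statements on the series, on what has been measured and on what is new or still open speak of the compounds shown alone.

In a functional assay on HCT-116 cells (Homo sapiens) for inhibition, read by MTT assay, with a stated time of 48 h (a lower number here means a stronger inhibitor, a higher number a weaker inhibitor), compound 1 (`COc1cc(-c2cc(-c3ccc(Br)cc3)nc(-c3ccccc3)n2)cc(OC)c1OC`) gives 4320 nM and carries a 4-bromophenyl group on the shared core. Compound 2 (`COc1ccc(-c2cc(-c3cc(OC)c(OC)c(OC)c3)nc(-c3ccccc3)n2)c(OC)c1`) has 2,4-dimethoxyphenyl at that aromatic carbon. Compound 2 stands at a limit of the assay (> 25000 nM) and has no number.

Compound 3 (`COc1cc(-c2cc(-c3ccc(O)cc3O)nc(-c3ccccc3)n2)cc(OC)c1OC`) is reached from compound 2 by 2,4-dihydroxyphenyl in place of 2,4-dimethoxyphenyl on an aromatic carbon with 2,4-dihydroxyphenyl in place of 2,4-dimethoxyphenyl on the same aromatic carbon. Among the compounds with values here, only one measured step bears on this exchange, namely an at least 5.7-fold higher number from compound 1 to compound 2 (0.76 log units; beyond the scatter) at this carbon. Within the data shown here, it shows that a change of group here can move the number beyond the scatter, but no hydroxyl-bearing compound has been measured yet. A move toward a lower number is therefore expected, smaller than the gap that separates the two measured compounds, and a result at the limit remains possible.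

The expected change is an at least 2.0-fold lower number from compound 2 to compound 3 (0.31 log units; beyond the scatter) in this assay and is only a rough estimate. Compound 3 is estimated at 12000 nM in this assay (expected range 3000 nM to 40000 nM).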

Compound 3, half-maximal inhibitory concentration: 5890 nM
The estimate for compound 3 lay 2.0-fold (0.31 log units) above the measured number; measured number inside the range.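

In this assay, 2,4-dihydroxyphenyl in place of 2,4-dimethoxyphenyl on this aromatic carbon gives an at least 4.2-fold lower number from compound 2 to compound 3 (0.62 log units; beyond the scatter), the first sign at this position that exchanging the two methoxy groups for hydroxyl groups alone can bring a compound back from the assay limit into the measurable range. Set against the 4-bromophenyl group on the same carbon, 2,4-dihydroxyphenyl gives a 1.4-fold higher number from compound 1 to compound 3 (0.13 log units; within the scatter), so these two groups are not told apart by this assay, although they differ in the substituents they carry. The size of the step from the dimethoxy compound remains a bound and not a full measure, since compound 2 has a limit and no number: the limit of > 25000 nM in this assay, at which 1 of the 3 values shown sits.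

Open, from the compounds shown here alone, is whether both hydroxyl groups are needed for this recovery, or whether a single one, as in 4-hydroxyphenyl or 2-hydroxyphenyl, would give the same result. Also open, going by these compounds, is whether any group on this carbon, such as a 4-aminophenyl or a 4-carboxyphenyl, would reach a number clearly lower than those of compound 1 and compound 3, and why the dimethoxy pattern stands apart.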